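Swapping cyclohexyl for benzyl on the shared core

A few compounds are considered here, and "the series" means these few. Any claim that something is new, unique, unknown or untested is made for them only; others in the source may bear on it.

Going by the values given here, compound 1 `O=Cc1ccc(-c2cn3ccnc3c(-c3ccc4ncn(C5CCCCC5)c4c3)n2)cc1` is tested in a functional assay on SR cells (Homo sapiens) for inhibition, read by sulforhodamine B assay, with a stated time of 48 h, tested at 10 uM (a higher number here means more inhibition at the concentration tested (going by the name of the read-out), a lower number less inhibition), where compound 1 gives 47.5%, the higher of the two numbers known. Compound 2 `c1csc(-c2cn3ccnc3c(-c3ccc4ncn(C5CCCCC5)c4c3)n2)c1` gives 27.2% in this assay, a change of a number 20.3 percentage points lower from compound 1 to compound 2 (beyond the scatter). Compound 3 `O=Cc1ccc(-c2cn3ccnc3c(-c3ccc4ncn(Cc5ccccc5)c4c3)n2)cc1` differs from compound 1 in one place: benzyl in place of cyclohexyl on an aromatic nitrogen. Among the compounds with values here, the only measured step touches a different part of the shared core, so no step bears on this change. Without a guide, no step beyond the scatter is expected: compound 3 is estimated at 45%, between 25% and 65%, a step of a number 2.5 percentage points lower from compound 1 to compound 3 (within the scatter).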

Compound 3, a percentage reported as inhibition, at one concentration (the size of the read-out at that concentration, not a potency): 47.5%
Compound 3: middle estimate off by 2.5 percentage points, on the low side; low and high end bracket the measured number.
By their numbers in this assay, from the lowest: compound 2; then compounds 1 and 3 (each within the scatter of the next).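

Going by these compounds alone, earlier compounds showed only that the group on the aromatic carbon matters. At the aromatic nitrogen, replacing cyclohexyl with benzyl gives no change at the digits printed from compound 1 to compound 3 (within the scatter) in this assay, so a non-aromatic ring and an aromatic ring carried on benzyl's extra carbon read alike here, with 4-formylphenyl in place. No available measurement offers an explanation for this. Still open, going by these compounds, is whether a longer chain, or an amine on the benzyl ring, would read alike at this nitrogen. Also open, on these data alone, is whether benzyl would read alike with thiophen-2-yl, the group in compound 2.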